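Methoxy removal on two cores of the isoxazoline series

This account rests on a few compounds, and the source may have more. Where it says the series, first, only, none or still open, it means among the compounds named here.

Measured so far:
- compound 1 `COc1cc(C2=NOC(c3c[nH]c4ccccc34)C2)cc(OC)c1OC`: in a functional assay on BXPC-3 cells (Homo sapiens) for inhibition, read by MTT assay, with a stated time of 48 h (on this read-out higher numbers stand for weaker inhibition and lower numbers for stronger inhibition), compound 1 gives 13500 nM
- compound 2 `COc1ccc(C2=NOC(c3c[nH]c4ccccc34)C2)cc1OC`: compound 2 gives > 100000 nM, which is a limit of the assay and not a number
- compound 3 `COc1ccc2c(C3CC(c4ccncc4)=NO3)c[nH]c2c1`: compound 3 gives 9500 nM

Compound 1 and compound 3 share the isoxazoline linked to an indole, but the difference between the two cores is not broken down here. Compound 3 and compound 1 lie within the scatter of each other, so no order between them is claimed.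

One structural change is made twice among these compounds. From compound 1 to compound 2 it is hydrogen in place of methoxy on an aromatic carbon and it made a step of an at least 7.4-fold higher number from compound 1 to compound 2 (0.86 log units; beyond the scatter). From compound 3 to compound 4 `c1ccc2c(C3CC(c4ccncc4)=NO3)c[nH]c2c1` it is hydrogen in place of methoxy on an aromatic carbon. The two place lines are not the same: in compound 1 the methoxy that leaves sits ortho to a methoxy group, meta to a large group and meta to a methoxy group, whereas in compound 3 it sits on a ring that is part of a fused or bridged system of two rings, meta and para to a fused ring. The change is therefore the same kind of change, not the same.

Compound 4 has not yet been measured in this assay. Resting on compound 1 and its step of an at least 7.4-fold higher number from compound 1 to compound 2 (0.86 log units; beyond the scatter), a step of a 3.7-fold higher number from compound 3 to compound 4 (0.57 log units; beyond the scatter) is expected from compound 3 to compound 4, the single earlier example being the only guide. The estimate for compound 4 is 35000 nM, expected between 8000 nM and 150000 nM.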

Compound 4, half-maximal inhibitory concentration: 30500 nM
The estimate for compound 4 lay 1.1-fold (0.06 log units) above the measured number; measured number inside the range.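

In this assay, hydrogen in place of methoxy on an aromatic carbon gives a 3.2-fold higher number from compound 3 to compound 4 (0.51 log units; beyond the scatter), so on this second core the change again goes with weaker inhibition. The direction of the step therefore carries over between the two cores, but its size cannot be compared, as one of the two steps rests on a limit of the assay and not on a number: the same change on two cores in this assay, an at least 7.4-fold higher number (0.86 log units; beyond the scatter) from compound 1 to compound 2 and a 3.2-fold higher number (0.51 log units; beyond the scatter) from compound 3 to compound 4; the limit leaves it open whether they differ The series offers only these two pairs, and the methoxy leaves a different place in each, so the observation holds for the core of compound 1 and the core of compound 3 and gives no rule for a third core or for other places on these rings.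

The compounds shown leave open whether a group other than methoxy on the same aromatic carbon, such as a hydroxyl, a fluorine or an ethoxy, would keep the numbers of compound 1 and compound 3 on either core. Also open, going by these compounds, is how an amine or a carboxylic acid in that place would read out in this assay.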